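Adding an acetyl group to a weakly active thiocarbamate

This account rests on a few compounds, and the source may have more. Where it says the series, first, only, none or still open, it means among the compounds named here.

Compound 2 `O=C1OCC[C@@H]1NC(=S)SCCOc1ccccc1` is the smaller member of this set. In a functional assay on PC-3 cells (Homo sapiens) for antiproliferative activity, read by MTT assay, with a stated time of 72 h (on this read-out higher numbers stand for weaker inhibition and lower numbers for stronger inhibition), compound 2 gives > 64000 nM, which is a limit of the assay rather than a number. Compound 1 `CCOc1ccccc1OCCSC(=S)N[C@H]1CCOC1=O` carries an ethoxy group on the aromatic ring; in this assay compound 1 gives 24100 nM. For the measured compounds named here, the one measured step, an at least 2.6-fold higher number from compound 1 to compound 2 (0.42 log units; beyond the scatter), shows that removing the ethoxy group weakens inhibition; its size is known only as a bound because of the limit of > 64000 nM in this assay, at which 1 of the 2 values shown sits. Compound 3 `CC(=O)c1ccc(OCCSC(=S)N[C@H]2CCOC2=O)cc1` differs from compound 2 by acetyl in place of hydrogen on an aromatic carbon. Going by the values given here, the only comparable step concerns a substituent on the same ring, and there the substituted compound inhibited more strongly, so a modest fall in the number is expected for compound 3, in the direction of an at least 1.8-fold lower number from compound 2 to compound 3 (0.26 log units; that floor lies within the scatter). Compound 3 is expected to give 35000 nM, within 12000 nM to 100000 nM.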

Compound 3, half-maximal inhibitory concentration: 46900 nM
The estimate for compound 3 lay 1.3-fold (0.13 log units) below the measured number; measured number inside the range.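

In this assay compound 3 gives a true number, 46900 nM, so a ring carrying acetyl para to a large group can still give a measurable, if weak, inhibition. Compound 2 stands at > 64000 nM, which is a limit of the assay and not a number. The data give an at least 1.3-fold lower number from compound 2 to compound 3 (0.13 log units; that floor lies within the scatter), so acetyl in place of hydrogen may change little or may change more, and the true size of the step stays unknown: the limit of > 64000 nM in this assay, at which 1 of the 3 values shown sits.

Going by these compounds, it remains open whether this result belongs to acetyl itself or would hold for other groups at the same place, such as methyl, an amine or a carboxylic acid. On these data alone, how acetyl compares with ethoxy also stays open: compound 1 and compound 3 differ in more than one place.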